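Working notes: butyl to isopropyl on the sulfur

The source may hold more compounds than are shown below. What is called first, only, known or untested is meant among the compounds shown, and "the series" means these compounds.

Compound 1 `CC[S+]([O-])CCCCN=C=S`: 8260 nM
Compound 2 `CCCC[S+]([O-])CCCCN=C=S`: 5840 nM

Among the measured compounds shown here, in a functional assay on MCF7 cells (Homo sapiens) for cytotoxicity, read by MTT assay, with a stated time of 72 h (a higher number here means a weaker inhibitor, a lower number a stronger inhibitor), compound 2 5840 nM stands within the scatter of compound 1, its only measured neighbour. Compound 3 `CC(C)[S+]([O-])CCCCN=C=S`, not yet measured, differs from compound 2 as follows: isopropyl in place of butyl on a sulfur. For the measured compounds named here, the one measured step bearing on this change is a 1.4-fold lower number from compound 1 to compound 2 (0.15 log units; within the scatter), which stays within the scatter. Going by the values given here, no isopropyl compound has been measured, so no step beyond the scatter is expected in this assay. The expected step is a 1.1-fold higher number from compound 2 to compound 3 (0.05 log units; within the scatter). For compound 3 the estimated value is 6500 nM, with an expected range of 3500 nM to 12000 nM.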

Compound 3, half-maximal inhibitory concentration: 8820 nM
For compound 3 the middle estimate is 1.4-fold (0.13 log units) below the measured one; the measured number falls inside the stated range.
By their numbers in this assay, from the lowest: compounds 2, 1 and 3 (each within the scatter of the next).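

Isopropyl in place of butyl on a sulfur gives a 1.5-fold higher number from compound 2 to compound 3 (0.18 log units; within the scatter) in this assay and methyl in place of hydrogen on a saturated chain carbon bound to a saturated chain carbon and a sulfur gives a 1.1-fold higher number from compound 1 to compound 3 (0.03 log units; within the scatter) in the same read-out. Ethyl, butyl and isopropyl on this sulfur thus all lie within the scatter of one another, and the isopropyl compound adds a third group without separating the series. No evidence is available that bears on these steps.

Going by these compounds, whether a phenyl ring, an amine or a longer chain such as octyl on the sulfur would give a step beyond the scatter remains open.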